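Thiophene in place of the methylphenyl amide on the pyrazole core

The compounds below may be only part of what the source reports. "The series", "measured", "known", "first", "only" and "open" are said of these compounds alone.

Measured so far:
compound 1 `O=C(Nc1cc(-c2ccccc2)nn1-c1ccccc1)c1ccc(F)cc1` 30 nM
compound 2 `O=C(Nc1cc(-c2ccccc2)nn1-c1ccccc1)c1cccc(Cl)c1` 40 nM
compound 3 `Cc1cccc(C(=O)Nc2cc(-c3ccccc3)nn2-c2ccccc2)c1` 90 nM

In an assay on CHO cells with metabotropic glutamate receptor 5 (Homo sapiens) as the target (a lower number here means that less compound is needed, a higher number that more compound is needed for the effect), compound 3 stands with the highest number of the three. Its steps to the others are a 3.0-fold higher number from compound 1 to compound 3 (0.48 log units; beyond the scatter) and a 2.3-fold higher number from compound 2 to compound 3 (0.35 log units; beyond the scatter), both beyond the scatter, while the step of a 1.3-fold higher number from compound 1 to compound 2 (0.12 log units; within the scatter) lies within it. Compound 4 `O=C(Nc1cc(-c2ccccc2)nn1-c1ccccc1)c1ccsc1` differs from compound 3 by thiophen-3-yl in place of 3-methylphenyl on a carbonyl carbon. All three measured steps concern the same aryl on the carbonyl carbon, and none exceeds a modest size. Among the compounds with values here, a thiophen-3-yl has no precedent here, so the expected step of a 1.8-fold lower number from compound 3 to compound 4 (0.26 log units; within the scatter) is modest and downward in this assay, given that compound 3 holds the weakest position. Compound 4 is estimated at 50 nM, within 20 nM to 150 nM.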

Compound 4, half-maximal effective concentration: 1800 nM
Compound 4: middle estimate off by 36-fold (1.56 log units), on the low side; the whole stated range lies below it.
By their numbers in this assay, from the lowest: compounds 1 and 2 (each within the scatter of the next); then compound 3; then compound 4.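

In this assay the aryl on the carbonyl carbon is far less forgiving than the 4-fluorophenyl, 3-chlorophenyl and 3-methylphenyl compounds suggested, since those three differ by modest steps at most. Thiophen-3-yl brings large steps against all three: a 20-fold higher number from compound 3 to compound 4 (1.30 log units; beyond the scatter) and a 45-fold higher number from compound 2 to compound 4 (1.65 log units; beyond the scatter) and a 60-fold higher number from compound 1 to compound 4 (1.78 log units; beyond the scatter) in this series. No available data explain this loss.

Open, as far as these compounds go, is whether the loss goes with the sulfur or with the five-membered ring. A furan-3-yl or an unsubstituted phenyl on the carbonyl carbon would separate the two.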